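Dropping a Carbon from the Ring Nitrogen Substituent

The source may report more compounds than this note shows. Statements on the series, on what has been measured and on what is new or still open speak of the compounds shown alone.

Two compounds share a core and an amide, and both were tested in a functional assay on the whole organism for inhibition, with Rattus norvegicus as the target, with a stated time of 90 min; a lower number here means that less compound is needed, a higher number that more compound is needed for the effect. Compound 1 `CN1C[C@@H]2[C@H](C1)[C@H]2CN(Cc1cccc(OC(F)(F)F)c1)C(=O)c1cn(C)cn1` gives 0.97 mg/kg. Compound 2 `CCN1C[C@@H]2[C@H](C1)[C@H]2CN(Cc1cccc(Cl)c1)C(=O)c1cn(C)cn1` gives 2.9 mg/kg, the higher of the two numbers, so more of compound 2 is needed than of compound 1, a gap that lies beyond the usual scatter. Compound 3 `CN1C[C@@H]2[C@H](C1)[C@H]2CN(Cc1cccc(Cl)c1)C(=O)c1cn(C)cn1` has not yet been measured. It differs from compound 2 in one place: hydrogen in place of methyl on a saturated chain carbon bound to an amine nitrogen in a ring. With this change compound 3 carries the same group on the ring nitrogen as compound 1 while keeping the chloro-substituted ring of compound 2. Compound 3 is expected to need somewhat less than compound 2, with the estimated step of a 1.8-fold lower number from compound 2 to compound 3 (0.26 log units; within the scatter), because compound 1 gives 0.97 mg/kg with that same methyl. The estimate for compound 3 in this assay is 1.6 mg/kg, within a range from 0.6 mg/kg to 4.5 mg/kg.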

Compound 3, dose for half-maximal effect: 8.6 mg/kg
Estimate against measurement, compound 3: 5.4-fold (0.73 log units) below; the whole stated range lies below it.
By their numbers in this assay, from the lowest: compound 1; then compound 2; then compound 3.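

In this assay, cutting ethyl to methyl, that is hydrogen in place of methyl on a saturated chain carbon bound to an amine nitrogen in a ring, gives a 3.0-fold higher number from compound 2 to compound 3 (0.47 log units; beyond the scatter), so with the chloro ring kept, the shorter group calls for more compound, not less. With methyl held fixed, chloro in place of trifluoromethoxy on an aromatic carbon gives an 8.9-fold higher number from compound 1 to compound 3 (0.95 log units; beyond the scatter), so methyl alone does not bring the low dose of compound 1, and within this pair that low dose goes with trifluoromethoxy. Nothing available explains either step. The compounds shown leave open whether the step from ethyl to methyl would be the same size with trifluoromethoxy on the ring. They also leave open whether a longer chain such as propyl would lower the dose further.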